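The compounds below may be only part of what the source reports. "The series", "measured", "known", "first", "only" and "open" are said of these compounds alone.

Compound 2 `C[C@H]1[C@H](NCc2cncs2)C[C@H]2C[C@@H]1C2(C)C` stands at the limit of an ADME assay on MDCK cells (Canis lupus familiaris) for cytotoxicity, read by microscopy, with a stated time of 48 h; a lower number here means that less compound is tolerated, a higher number that more compound is tolerated: in this assay compound 2 gives > 100000 nM, a limit rather than a number (the limit of > 100000 nM in this assay, at which 1 of the 3 values shown sits). The two thiophene analogues sit lower. In this assay compound 1 `Cc1ccsc1CN[C@@H]1C[C@H]2C[C@@H]([C@H]1C)C2(C)C` gives 10000 nM, and compound 3 `CCc1csc(CN[C@@H]2C[C@H]3C[C@@H]([C@H]2C)C3(C)C)c1` gives 25000 nM. Within the data shown here, the one measured step that bears here is an at least 10-fold higher number from compound 1 to compound 2 (1.00 log units; beyond the scatter), where a thiophene gave way to a thiazole. Compound 4 `C[C@H]1[C@H](NCc2ccc(Br)s2)C[C@H]2C[C@@H]1C2(C)C` runs that change back toward a thiophene: 5-bromothiophen-2-yl in place of 1,3-thiazol-5-yl on a saturated chain carbon bound to an amine nitrogen. Since the thiazole raised the number in the measured step, the return to a thiophene is expected to lower it, by roughly an at least 5.0-fold lower number from compound 2 to compound 4 (0.69 log units; beyond the scatter). Compound 4 is therefore estimated at 20000 nM in this assay, within a range from 5000 nM to 100000 nM.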

Compound 4, minimum cytotoxic concentration: 43000 nM
Compound 4: middle estimate off by 2.2-fold (0.33 log units), on the low side; low and high end bracket the measured number.
By their numbers in this assay, from the lowest: compound 1; then compounds 3 and 4 (each within the scatter of the next). At a limit, above all of these: compound 2.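

In this assay, the return to a thiophene lowers the number, with an at least 2.3-fold lower number from compound 2 to compound 4 (0.36 log units; beyond the scatter), yet 5-bromothiophen-2-yl does not behave like 3-methylthiophen-2-yl, with a 4.3-fold higher number from compound 1 to compound 4 (0.63 log units; beyond the scatter), so the number at this position follows the thiophene's substituents and not the ring alone. Compound 2 remains a limit, so the first of these steps is a bound: the limit of > 100000 nM in this assay, at which 1 of the 4 values shown sits. The compounds shown leave open whether the bromine or its location on the ring sets the number, and where a thiophene bearing chlorine, or no substituent, would fall.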